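Swapping oxan-4-yl for chloro on a rapidly cleared compound

This account rests on a few compounds, and the source may have more. Where it says the series, first, only, none or still open, it means among the compounds named here.

In an ADME assay on microsomes from liver (Homo sapiens) for metabolic stability, read by LC-MS, using NADPH, with a stated time of 30 min, tested at 1 uM (a lower number here means slower removal, a higher number faster removal of the compound), compound 3 `NC1=N[C@@]2(CO1)c1cc(NC(=O)c3ccc(Cl)cn3)ccc1Oc1cnc(C3CCOCC3)cc12` gives 80 mL.min-1.g-1 and holds the highest number measured. Compound 1 `Cc1cc2c(cn1)Oc1ccc(NC(=O)c3ccc(Cl)cn3)cc1[C@@]21COC(N)=N1` stands at 16 mL.min-1.g-1 by comparison. For compound 2 `COc1cc2c(cn1)Oc1ccc(NC(=O)c3ccc(Cl)cn3)cc1[C@@]21COC(N)=N1` the reading < 14 mL.min-1.g-1 is a limit, not a number.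

The change to compound 4 `NC1=N[C@@]2(CO1)c1cc(NC(=O)c3ccc(Cl)cn3)ccc1Oc1cnc(Cl)cc12` is chloro in place of oxan-4-yl on an aromatic carbon and puts chloro in place of oxan-4-yl on an aromatic carbon. Within the data shown here, two measured steps bear on this: a 5.0-fold higher number from compound 1 to compound 3 (0.70 log units; beyond the scatter) and an at least 5.7-fold higher number from compound 2 to compound 3 (0.75 log units; beyond the scatter) both climb beyond the scatter, while an at least 1.1-fold lower number from compound 1 to compound 2 (0.05 log units; that floor lies within the scatter) does not leave it. Chloro itself is untested here. With a 5.0-fold higher number from compound 1 to compound 3 (0.70 log units; beyond the scatter) as the closest guide, the step expected is a 4.0-fold lower number from compound 3 to compound 4 (0.60 log units; beyond the scatter) and runs downward. Compound 4 is expected near 20 mL.min-1.g-1 within a range of 10 mL.min-1.g-1 to 40 mL.min-1.g-1 and may return only a limit.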

Compound 4, intrinsic clearance in microsomes: 37 mL.min-1.g-1
Beside the measured number, compound 4's estimate is 1.9-fold (0.27 log units) below it; measured number inside the range.
By their numbers in this assay, from the lowest: compound 1; then compound 4; then compound 3. At a limit, below all of these: compound 2.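

In this assay, the step of a 2.2-fold lower number from compound 3 to compound 4 (0.33 log units; beyond the scatter) shows that taking oxan-4-yl off this position lowers the number, yet the step of a 2.3-fold higher number from compound 1 to compound 4 (0.36 log units; beyond the scatter) shows that chloro does not bring it down to the level of methyl. So losing the ring alone does not account for the full gap between these groups. Compound 2 reads only as a limit, so an at least 2.6-fold higher number from compound 2 to compound 4 (0.42 log units; beyond the scatter) is a floor on that step: the limit of < 14 mL.min-1.g-1 in this assay, at which 1 of the 4 values shown sits. From the compounds shown here alone, whether an amine or a nitrile here would give a lower number stays open. The compounds shown also cannot say why chloro lands where it does.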